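Swapping the Aryl Group on a Shared Sulfone Scaffold

The source may report more compounds than this note shows. Statements on the series, on what has been measured and on what is new or still open speak of the compounds shown alone.

Compound 1 `O=S(=O)(/C=C/c1ccc(Cl)cc1Cl)Cc1ccc(Nc2ncnc3ccccc23)cc1` and compound 2 `O=S(=O)(/C=C/c1ccc(C(F)(F)F)cc1F)Cc1ccc(Nc2ncnc3ccccc23)cc1` share one core and differ only by 2-fluoro-4-(trifluoromethyl)phenyl in place of 2,4-dichlorophenyl on a double-bonded chain carbon bound to a double-bonded chain carbon. In a functional assay on PC-3 cells (Homo sapiens) (a higher number here means a weaker inhibitor of growth, a lower number a stronger inhibitor of growth), compound 1 gives 19000 nM, while compound 2 gives 100000 nM, so this change produced a 5.3-fold higher number from compound 1 to compound 2 (0.72 log units; beyond the scatter). Compound 3 `O=S(=O)(/C=C/c1ccc(Cl)cc1Cl)Cc1ccc(Nc2ncnc3cc(Cl)ccc23)cc1` carries a second core, which differs from the core of compound 1 by chloro in place of hydrogen on an aromatic carbon; in this assay compound 3 gives 38000 nM, which amounts to a 2.0-fold higher number from compound 1 to compound 3 (0.30 log units; within the scatter). Compound 4 `O=S(=O)(/C=C/c1ccc(C(F)(F)F)cc1F)Cc1ccc(Nc2ncnc3cc(Cl)ccc23)cc1` has not yet been measured. It stands to compound 3 as compound 2 stands to compound 1, the difference being (2-fluoro-4-(trifluoromethyl)phenyl in place of 2,4-dichlorophenyl on a double-bonded chain carbon bound to a double-bonded chain carbon), made at the same place in both pairs. With a single earlier example of this change to go on, the expectation is that it acts in a similar way on the second core. The step from compound 3 to compound 4 in this assay is estimated at a 3.9-fold higher number from compound 3 to compound 4 (0.60 log units; beyond the scatter), resting on a 5.3-fold higher number from compound 1 to compound 2 (0.72 log units; beyond the scatter) carried over to the second core. Compound 4 is expected to give about 150000 nM in this assay, most likely between 60000 nM and 400000 nM.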

Compound 4, concentration for 50% growth inhibition: > 100000 nM
Compound 4: no number, only a limit (the forecaster's own chance of this, stated with the estimate: 35%); the middle value does not contradict the limit.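

In this assay compound 4 gives > 100000 nM as its reading, which is a limit of the assay and not a number. Even so, replacing 2,4-dichlorophenyl with 2-fluoro-4-(trifluoromethyl)phenyl moves the result in the same direction on the second core, with an at least 2.6-fold higher number from compound 3 to compound 4 (0.42 log units; beyond the scatter) on that core, so in this single pair of examples the direction carries over from one core to the other. This does not show that the size carries over, and chloro in place of hydrogen on an aromatic carbon gives a number no lower from compound 2 to compound 4 (the limit leaves the size open) with no size to read, so only the direction of the change is shared: the same change on two cores in this assay, a 5.3-fold higher number (0.72 log units; beyond the scatter) from compound 1 to compound 2 and an at least 2.6-fold higher number (0.42 log units; beyond the scatter) from compound 3 to compound 4; the limit leaves it open whether they differ.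

The compounds shown leave open whether the same swap would act alike on a core bearing a methoxy group or an amine in place of the chloro. They also leave open how an aryl group carrying a carboxylic acid would read in this assay on either core.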